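A few compounds are considered here, and "the series" means these few. Any claim that something is new, unique, unknown or untested is made for them only; others in the source may bear on it.

Measured compounds in an assay on isolated protein for inhibition of DNA topoisomerase 1 (Homo sapiens), with a stated time of 30 min, tested at 100 uM; on this read-out lower numbers stand for a weaker effect and higher numbers for a stronger effect at the one concentration tested:
compound 1 `Oc1ccccc1-c1cc(-c2ccsc2)cc(-c2ccccc2O)n1` gives 0%
compound 2 `Oc1ccccc1-c1cc(-c2ccco2)cc(-c2ccccc2O)n1` gives 89.1%

Going by the values given here, compound 2 stands highest of the two numbers in this assay; its only neighbour is compound 1, and the step of a number 89.1 percentage points higher from compound 1 to compound 2 (beyond the scatter) is large and beyond the scatter. That step swaps thiophen-3-yl for furan-2-yl, so it changes the heteroatom and the point of attachment at the same time and cannot be split into the two parts.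

Compound 3 `Oc1ccccc1-c1cc(-c2ccoc2)cc(-c2ccccc2O)n1` is not yet measured. It differs from compound 2 in one place: furan-3-yl in place of furan-2-yl on an aromatic carbon. Among the compounds with values here, only the step from compound 1 to compound 2 bears on this change, and only indirectly, since here the heteroatom is kept and the attachment alone is moved. Compound 1, carrying thiophen-3-yl, gave 0%, and the attachment in thiophen-3-yl matches that in furan-3-yl, so part of the gain seen for compound 2 may be lost. Within the data shown here, the step is expected to be a number 49.1 percentage points lower from compound 2 to compound 3 (beyond the scatter) in this assay, with wide uncertainty because the one relevant step a number 89.1 percentage points higher from compound 1 to compound 2 (beyond the scatter) mixes two changes. Compound 3 is estimated at 40% in this assay, within a range from 5% to 85%.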

Compound 3, a percentage reported as inhibition, at one concentration (the size of the read-out at that concentration, not a potency): 1%
Estimate against measurement, compound 3: 39 percentage points above; measured number outside the range, below it.
By their numbers in this assay, from the lowest: compounds 1 and 3 (each within the scatter of the next); then compound 2.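

In this assay, the attachment of the furan ring to the carbon opposite the ring nitrogen decides the outcome: with the same atoms joined differently, the result is a number 88.1 percentage points lower from compound 2 to compound 3 (beyond the scatter), which is a large loss. The earlier mixed change can now be read in part, as exchanging thiophen-3-yl for furan-3-yl at the matching attachment gives a number 1 percentage points higher from compound 1 to compound 3 (within the scatter), so at this attachment the swap of ring heteroatom makes no difference that can be told from the scatter, and among the three compounds only the furan-2-yl of compound 2 stands apart. Nothing at hand accounts for this sharp dependence on the point of attachment.

Thiophen-2-yl would show whether the favourable attachment holds with sulfur in the ring, which the present compounds leave open, since the effect of the heteroatom has been read only at the attachment that gives little inhibition. On these data alone, it is also open whether furan-2-yl tolerates any added group, such as a methyl or an aminomethyl on the furan ring, and whether the stronger effect of compound 2 holds at other concentrations, since the read-out comes from a single concentration.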